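Series notes: compound 2 to compound 4

This account rests on a few compounds, and the source may have more. Where it says the series, first, only, none or still open, it means among the compounds named here.

Three compounds of the shared core have numbers in a functional assay on HCT-116 cells (Homo sapiens) for antiproliferative activity, read by MTT assay, with a stated time of 72 h; on this read-out higher numbers stand for weaker inhibition and lower numbers for stronger inhibition. Compound 1 `O=C1COc2ccc(-c3cnc(Cl)c(NS(=O)(=O)c4ccc(F)cc4)c3)cc2N1c1ccccc1` gives 39800 nM, compound 2 `O=C1COc2ccc(-c3cnc(Cl)c(NS(=O)(=O)c4ccc(F)cc4)c3)cc2N1c1ccc(Cl)cc1` gives 27900 nM, and compound 3 `COc1ncc(-c2ccc3c(c2)N(c2ccc(Cl)cc2)C(=O)CO3)cc1NS(=O)(=O)c1ccc(F)cc1` gives 19200 nM. Compound 2 stands second highest of the three; the gap to compound 1, a 1.4-fold lower number from compound 1 to compound 2 (0.15 log units; within the scatter), and the gap to compound 3, a 1.5-fold lower number from compound 2 to compound 3 (0.16 log units; within the scatter), both lie within the scatter. Compound 4 `O=C1COc2ccc(-c3cnc(Cl)c(NS(=O)(=O)c4ccc(F)cc4)c3)cc2N1C1CC1` differs from compound 2 by cyclopropyl in place of 4-chlorophenyl on an amide-type nitrogen in a ring. For the measured compounds named here, only the step from compound 1 to compound 2 touches the group on this amide-type nitrogen, and it stayed within the scatter; no measured step replaces the aromatic ring there with a three-membered ring. Nothing measured therefore points to movement beyond the scatter, though the untested swap leaves the range wide. Compound 4 is expected at 30000 nM, between 10000 nM and 90000 nM. The expected step is a 1.1-fold higher number from compound 2 to compound 4 (0.03 log units; within the scatter).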

Compound 4, half-maximal inhibitory concentration: 12400 nM
Estimate against measurement, compound 4: 2.4-fold (0.38 log units) above, and the stated range covers the measured number.
By their numbers in this assay, from the lowest: compounds 4, 3, 2 and 1 (each within the scatter of the next, the first and the last beyond it).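

For the compounds shown here, this is the first change at the amide-type nitrogen that moves the number beyond the scatter: a 2.3-fold lower number from compound 2 to compound 4 (0.35 log units; beyond the scatter), and with phenyl as the group replaced, a 3.2-fold lower number from compound 1 to compound 4 (0.51 log units; beyond the scatter). Both steps are modest, but they show that within these compounds an aromatic ring on this nitrogen is not needed to keep the antiproliferative read-out, since the non-aromatic cyclopropyl gives the lower numbers. Nothing available here accounts for the shift.

Still open, from the compounds shown here alone, is how methyl, a longer chain such as n-butyl, or a cyclohexyl ring would read on this nitrogen. Also open, going by these compounds, is whether cyclopropyl gives a similar step when methoxy replaces chloro on the aromatic carbon, as in compound 3.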